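Piperidin-4-yl to isopropyl: an expected loss of affinity

A few compounds are considered here, and "the series" means these few. Any claim that something is new, unique, unknown or untested is made for them only; others in the source may bear on it.

In an assay for binding affinity to Melanocortin receptor 4 (Homo sapiens) (a higher number here means a weaker inhibitor, a lower number a stronger inhibitor), three compounds have been measured:
- compound 1 `COc1ccc(Br)cc1CCc1c(F)cccc1C(=O)/N=C(\N)NCCN1CCCC1` gives 190 nM
- compound 2 `COc1ccc(Br)cc1CCc1c(F)cccc1C(=O)/N=C(\N)NCCC1CCCCC1` gives 2600 nM
- compound 3 `COc1ccc(Br)cc1CCc1c(F)cccc1C(=O)/N=C(\N)NCC1CCNCC1` gives 13 nM

Compound 3 stands lowest of the three, with compound 1 nearest and compound 2 furthest away, both separated from it by steps beyond the scatter. Two steps lead into compound 3: a 15-fold lower number from compound 1 to compound 3 (1.16 log units; beyond the scatter) and a 200-fold lower number from compound 2 to compound 3 (2.30 log units; beyond the scatter). In both, a ring bearing a nitrogen replaces a group without one at the carbon bound to the amine nitrogen, and in both the number falls sharply.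

Compound 4 `COc1ccc(Br)cc1CCc1c(F)cccc1C(=O)/N=C(\N)NCC(C)C` makes the opposite move: isopropyl in place of piperidin-4-yl on a saturated chain carbon bound to an amine nitrogen. As in the move from compound 2, the ring with its nitrogen is gone, and compound 4 keeps only a small branched chain. The steps into compound 3 therefore point to a large rise in this assay, in the direction of compound 2. For compound 4 the expected step is a 150-fold higher number from compound 3 to compound 4 (2.19 log units; beyond the scatter), giving an estimated 2000 nM with a range from 500 nM to 8000 nM.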

Compound 4, inhibition constant: 770 nM
For compound 4 the middle estimate is 2.6-fold (0.41 log units) above the measured one, and the stated range covers the measured number.
By their numbers in this assay, from the lowest: compound 3; then compound 1; then compound 4; then compound 2.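

Taking out the piperidin-4-yl gives a 59-fold higher number from compound 3 to compound 4 (1.77 log units; beyond the scatter), so a small group without nitrogen does not come close to matching that ring. Yet the all-carbon groups are not equal: swapping cyclohexylmethyl for isopropyl gives a 3.4-fold lower number from compound 2 to compound 4 (0.53 log units; beyond the scatter). Going the other way, replacing (pyrrolidin-1-yl)methyl with isopropyl gives a 4.1-fold higher number from compound 1 to compound 4 (0.61 log units; beyond the scatter), a much smaller cost than losing the piperidin-4-yl, so the groups containing nitrogen also differ widely in what they add.

Still open, on these data alone, is whether the ring or its nitrogen matters more, which tetrahydropyran-4-yl or a short open-chain amine at this place could help separate. Nothing measured here explains why these numbers differ.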